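Dichlorohydroxybenzyl amide on the piperidine core

The source may hold more compounds than are shown below. What is called first, only, known or untested is meant among the compounds shown, and "the series" means these compounds.

Working notes. The series shares a core built on a pyrrole bearing a trifluoromethylphenyl group; compound 1 `O=C(NCc1ccc(Cl)cc1Cl)N1CCN(Cc2ccn(-c3ccc(C(F)(F)F)cc3)c2)CC1` and compound 2 `O=C(NCC1(O)CCCCC1)C1CCN(Cc2ccn(-c3ccc(C(F)(F)F)cc3)c2)CC1` have been measured in an assay on HEK293 cells for displacement of a labelled ligand from melanin-concentrating hormone receptor 1 (Homo sapiens); a lower number here means a stronger inhibitor, a higher number a weaker inhibitor. Compound 1 gives 8 nM, and compound 2 gives 40 nM. Compound 2 thus stands at the higher of the two numbers, and the gap between compound 1 and compound 2 is beyond the scatter.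

The next step keeps the core of compound 2 and exchanges the amide substituent: compound 3 `O=C(NCc1c(O)cc(Cl)cc1Cl)C1CCN(Cc2ccn(-c3ccc(C(F)(F)F)cc3)c2)CC1` carries 2,4-dichloro-6-hydroxyphenyl in place of 1-hydroxycyclohexyl on a saturated chain carbon bound to an amide-type nitrogen. Among the compounds with values here, no measured pair differs in exactly this way, so the size of the step rests on the two values above. Since compound 1, which also carries an aryl bearing two chlorines, reaches 8 nM, the aryl in compound 3 is expected to move the number downward rather than upward, by an amount beyond the scatter.

The step from compound 2 to compound 3 is estimated as a 4.0-fold lower number from compound 2 to compound 3 (0.60 log units; beyond the scatter). Compound 3 is therefore expected near 10 nM, with a range of 3 nM to 40 nM.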

Compound 3, half-maximal inhibitory concentration: 144 nM
For compound 3 the middle estimate is 14-fold (1.16 log units) below the measured one; measured number outside the range, above it.
By their numbers in this assay, from the lowest: compound 1; then compound 2; then compound 3.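

In this assay, 2,4-dichloro-6-hydroxyphenyl in place of 1-hydroxycyclohexyl on a saturated chain carbon bound to an amide-type nitrogen gives a 3.6-fold higher number from compound 2 to compound 3 (0.56 log units; beyond the scatter), so this position responds to the exchange, and in this pair the aromatic group with two chlorines is the weaker of the two. The exchange leaves the counts of hydrogen-bond donors and acceptors unchanged and no net charge on either group, while the non-aromatic carbon ring gives way to an aromatic one and two chlorine atoms enter, so the step arises without any change in those counts. No measurement at hand bears on why the number rises at this position.

The pair changes the ring and the chlorines together, so their separate shares in the step remain unresolved; a plain phenyl group or a 2,4-dichlorophenyl group at this place would be needed to divide them. Also open, from the compounds shown here alone, is how this position responds to groups of another kind, such as an amine or a carboxylic acid, or to a longer chain.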